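The compounds below may be only part of what the source reports. "The series", "measured", "known", "first", "only" and "open" are said of these compounds alone.

Among the compounds with values here, compound 2 `COc1ccc(-c2cc(C)c(N3CCN(c4ncccn4)CC3)nn2)cc1` gives the lower of the two numbers measured so far in a functional assay on BV-2 cells (Mus musculus) for inhibition, read by ELISA, with a stated time of 16 h (on this read-out higher numbers stand for weaker inhibition and lower numbers for stronger inhibition), where it reaches 5200 nM; its only neighbour, compound 1 `Cc1cc(-c2cccc(F)c2)nnc1N1CCN(c2ncccn2)CC1`, gives 33500 nM in this assay. Within the data shown here, the single step that joins them, a 6.4-fold lower number from compound 1 to compound 2 (0.81 log units; beyond the scatter), shows that the group on this aromatic carbon can move the number well beyond the scatter.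

Compound 3 `Cc1cc(-c2cccnc2)nnc1N1CCN(c2ncccn2)CC1` differs from compound 2 in one place: pyridin-3-yl in place of 4-methoxyphenyl on an aromatic carbon. Among the measured compounds shown here, no measured step covers this exact exchange, so the expectation rests on the size of the change seen between compound 1 and compound 2 and on the fact that the entering group is smaller and carries its acceptor in the ring itself rather than on a methoxy group. Because the step of a 6.4-fold lower number from compound 1 to compound 2 (0.81 log units; beyond the scatter) shows the number is sensitive to this position, the author expects a shift rather than a flat result, most likely toward a higher number, with a step of about a 2.3-fold higher number from compound 2 to compound 3 (0.36 log units; beyond the scatter). Compound 3 is therefore estimated at 12000 nM in this assay, within a range from 4000 nM to 40000 nM.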

Compound 3, half-maximal inhibitory concentration: > 100000 nM
Compound 3 was reported as a limit; the forecaster's own chance of this, stated with the estimate: 10%; at least 8.3-fold (0.92 log units) between middle value and limit.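

The reading for compound 3 in this assay is a limit and not a number: the limit of > 100000 nM in this assay, at which 1 of the 3 values shown sits. Even so, the step of an at least 19-fold higher number from compound 2 to compound 3 (1.28 log units; beyond the scatter) is larger than any seen before at this position, and the step of an at least 2.9-fold higher number from compound 1 to compound 3 (0.47 log units; beyond the scatter) places pyridin-3-yl on the weak side of 3-fluorophenyl as well, so the three groups now fall in one order, with 4-methoxyphenyl giving the lowest number and pyridin-3-yl the highest. Within the data shown here, the earlier pair showed only that the number moves with the group on this aromatic carbon; this result adds that a change can take the number out to the limit of the assay, although 4-methoxyphenyl and pyridin-3-yl have the same counts of hydrogen-bond donors and acceptors and neither carries a net charge.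

As far as these compounds go, how far compound 3 lies beyond its limit stays open, and with it the true size of both new steps. The compounds shown also leave open whether the lower number of compound 2 belongs to the methoxy group or to the carbon-only ring, a question that an unsubstituted phenyl, a 4-ethoxyphenyl or a 4-aminophenyl group would address.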